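The source may hold more compounds than are shown below. What is called first, only, known or untested is meant among the compounds shown, and "the series" means these compounds.

In an ADME assay on MDCK cells (Canis lupus familiaris) for cytotoxicity, read by microscopy, with a stated time of 48 h (a lower number here means that less compound is tolerated, a higher number that more compound is tolerated), compound 2 `C[C@H]1[C@H](NCc2sccc2Br)C[C@H]2C[C@@H]1C2(C)C` gives 50000 nM, the highest of the three numbers measured. Compound 1 `C[C@H]1[C@H](NCc2sccc2-c2ccccc2)C[C@H]2C[C@@H]1C2(C)C` gives 12500 nM and compound 3 `C[C@H]1[C@H](NCc2sccc2C2CCCC2)C[C@H]2C[C@@H]1C2(C)C` gives 12500 nM. Going by the values given here, the measured steps are a 4.0-fold higher number from compound 1 to compound 2 (0.60 log units; beyond the scatter), a 4.0-fold lower number from compound 2 to compound 3 (0.60 log units; beyond the scatter) and no change at the digits printed from compound 1 to compound 3 (within the scatter); only the step carrying bromo lies beyond the scatter. Compound 4 `Cc1n[nH]cc1CN[C@@H]1C[C@H]2C[C@@H]([C@H]1C)C2(C)C` changes the ring itself: 3-methyl-1H-pyrazol-4-yl in place of 3-bromothiophen-2-yl on a saturated chain carbon bound to an amine nitrogen. Among the compounds with values here, no measured step replaces the whole ring, so the bromo steps bear on it only indirectly, and the loss of bromo suggests a move back toward the two lower numbers. Compound 4 is therefore expected to show a 2.0-fold lower number from compound 2 to compound 4 (0.30 log units; within the scatter), giving an estimated 25000 nM with a range from 10000 nM to 60000 nM.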

Compound 4, minimum cytotoxic concentration: > 100000 nM
Compound 4: only a limit was reported; the forecaster's own chance of this, stated with the estimate: 20%; middle value at least 4.0-fold (0.60 log units) away from the limit.
By their numbers in this assay, from the lowest: compounds 1 and 3 (each within the scatter of the next); then compound 2. At a limit, above all of these: compound 4.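

In this assay compound 4 gives > 100000 nM, which is a limit of the assay and not a number. Going by these compounds alone, with 3-methyl-1H-pyrazol-4-yl in place of 3-bromothiophen-2-yl, the step is an at least 2.0-fold higher number from compound 2 to compound 4 (0.30 log units; that floor lies within the scatter), so this place accepts a ring with a hydrogen-bond donor and no bromine without a lower number, which the earlier compounds could not show. The true size of the step cannot be read from a limit: the limit of > 100000 nM in this assay, at which 1 of the 4 values shown sits.

From the compounds shown here alone, whether the methyl group of compound 4 contributes remains open. So does whether a pyridine or imidazole ring here would also reach the limit.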